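The compounds below may be only part of what the source reports. "The series", "measured", "known", "first", "only" and "open" are said of these compounds alone.

In an ADME assay on Caco-2 cells (Homo sapiens) for permeability (a higher number here means that the compound crosses the layer faster, a lower number that the compound crosses the layer more slowly), compound 3 (`CC(C)c1ccc(/C=C/C(=O)N[C@@H]2O[C@H](CO)[C@@H](O)[C@H](O)[C@H]2O)cc1`) gives 98.5 nm/s and compound 2 (`CC(C)(C)c1ccc(/C=C/C(=O)N[C@@H]2O[C@H](CO)[C@@H](O)[C@H](O)[C@H]2O)cc1`) gives 87.7 nm/s and these two numbers lie within the scatter of each other. Compound 1 (`O=C(CCNC(=O)c1ccc(F)c(F)c1)N[C@@H]1O[C@H](CO)[C@@H](O)[C@H](O)[C@H]1O`) gives 31.4 nm/s in the same test, a lower number than that of compound 3 and one beyond the scatter.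

Compound 4 (`CCc1ccc(/C=C/C(=O)N[C@@H]2O[C@H](CO)[C@@H](O)[C@H](O)[C@H]2O)cc1`) has not yet been measured. It differs from compound 3 in one place: hydrogen in place of methyl on a saturated chain carbon bound to an aromatic carbon and a saturated chain carbon is the whole of the change, which turns isopropyl to ethyl by setting hydrogen in place of methyl on a saturated chain carbon bound to an aromatic carbon and a saturated chain carbon.

Going by the values given here, only one measured step is of the same kind, again hydrogen in place of methyl on a saturated chain carbon bound to an aromatic carbon, though there the carbon also carries one more saturated chain carbon. That step, a 1.1-fold higher number from compound 2 to compound 3 (0.05 log units; within the scatter) on the numbers, stays within the scatter. A single step is thin evidence, but on it no move beyond the scatter is expected in this assay for the new change. The expected step is a 1.1-fold lower number from compound 3 to compound 4 (0.03 log units; within the scatter) and no direction can be claimed for it. For compound 4 the estimate is 92 nm/s with an expected range from 55 nm/s to 150 nm/s as its limits.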

Compound 4, apparent permeability: 94.7 nm/s
Compound 4: the middle estimate sits 1.0-fold (0.01 log units) below what was measured, within the range that was stated.
By their numbers in this assay, from the lowest: compound 1; then compounds 2, 4 and 3 (each within the scatter of the next).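

In this assay, the second removal of a methyl on this saturated chain carbon, turning isopropyl to ethyl, gives a 1.0-fold lower number from compound 3 to compound 4 (0.02 log units; within the scatter), so the position now tolerates this change twice over with no move beyond the scatter, where earlier only the step from tert-butyl to isopropyl had shown this. Taken as a whole, the change of ethyl in place of tert-butyl on an aromatic carbon gives a 1.1-fold higher number from compound 2 to compound 4 (0.03 log units; within the scatter), which shows that even the two methyl changes added together stay within the scatter, and that ethyl, isopropyl and tert-butyl at this place fall in no order in this test. Nothing given here bears on the reason for this closeness.

The compounds shown leave open whether the same holds for a plain methyl, a longer chain such as n-butyl, or a group of another kind such as an amine or a carboxylic acid at this place on the aromatic ring. Going by these compounds alone, they also leave open whether these alkyl changes would behave in the same way on a core other than the one shared by compound 2, compound 3 and compound 4.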